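Permeability notes on the series: step to compound 4

This account rests on a few compounds, and the source may have more. Where it says the series, first, only, none or still open, it means among the compounds named here.

Measured so far, in an ADME assay on Caco-2 cells (Homo sapiens) for permeability, in the apical to basolateral direction; on this read-out lower numbers stand for lower permeability and higher numbers for higher permeability:
- compound 1, `CNC(=O)c1cc(Oc2ccc3oc(Nc4ccccc4F)nc3c2)ccn1`: compound 1 gives 10 10^-6 cm/s
- compound 2, `CCc1ccc(Nc2nc3cc(Oc4ccnc(C(=O)NC)c4)ccc3o2)cc1`: compound 2 gives 10 10^-6 cm/s
- compound 3, `CNC(=O)c1cc(Oc2ccc3oc(Nc4ccc(Oc5ccccc5)cc4)nc3c2)ccn1`: compound 3 gives 10 10^-6 cm/s

Compound 3 stands level with compounds 1 and 2 at the digits shown in this assay; its nearest neighbour is compound 1 and its furthest compound 2, and both gaps lie within the scatter.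

The next compound, compound 4, is `CNC(=O)c1cc(Oc2ccc3oc(Nc4ccc(N(C)C)cc4)nc3c2)ccn1`. Against compound 3 the change is dimethylamino in place of phenoxy on an aromatic carbon.

Going by the values given here, two measured steps bear on this position on the ring attached to the amine nitrogen. The step of no change at the digits printed from compound 1 to compound 2 (within the scatter) swapped the whole aryl group on that nitrogen without effect. The step of no change at the digits printed from compound 2 to compound 3 (within the scatter) replaced ethyl by phenoxy at the same aromatic carbon that now carries dimethylamino, again without effect. Among the compounds with values here, no measured step covers dimethylamino itself, so the expectation rests on the flatness of these two steps only; on that basis no step beyond the scatter is expected in this assay, in either direction.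

Compound 4 is therefore estimated at 10 10^-6 cm/s in this assay, with a range of 5 10^-6 cm/s to 20 10^-6 cm/s. The step this estimate implies is no change at the digits printed from compound 3 to compound 4 (within the scatter), expected to stay within the scatter.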

Compound 4, apparent permeability: 10 10^-6 cm/s
The estimate for compound 4 equals the measured number at the digits printed; the range from low to high includes it.
By their numbers in this assay, from the lowest: compounds 1, 2, 3 and 4 (each within the scatter of the next).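

Working notes on compound 4: the change at this aromatic carbon, para to a large group, removes a whole six-membered aromatic ring of carbon only and goes from 7 heavy atoms in phenoxy to 3 in dimethylamino, with nitrogen entering and oxygen leaving, yet this assay shows no change at the digits printed from compound 3 to compound 4 (within the scatter) for this step. Going by these compounds alone, the position therefore tolerates a much smaller group here as well as the larger one, and the comparison with the alkyl group gives no change at the digits printed from compound 2 to compound 4 (within the scatter) while the exchange of the whole aryl group gives no change at the digits printed from compound 1 to compound 4 (within the scatter) and no compound among the four goes against this flat picture. Nothing available here bears on why the read-out stays level across these groups.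

The compounds shown leave open whether a carboxylic acid or a longer chain ending in an amine at this aromatic carbon would also stay level in this assay. On these data alone, all four share the core and the methyl amide, so the response to replacing that amide with a nitrile or a carboxylic acid also remains open.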